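Cyclobutyl in place of propyl on the nitrogen-bound chain

The compounds below may be only part of what the source reports. "The series", "measured", "known", "first", "only" and "open" are said of these compounds alone.

For the measured compounds named here, in a functional assay on CHO cells for positive allosteric modulation of metabotropic glutamate receptor 2 (Homo sapiens), with a stated time of 30 min (a higher number here means that more compound is needed for the effect, a lower number that less compound is needed), compound 2 `CCCCn1ccc(N2CCC(c3ccccc3)CC2)c(C#N)c1=O` gives 95 nM, the lowest of the two numbers so far, while compound 1 `CC(C)CCn1ccc(N2CCc3ccccc3C2)c(C#N)c1=O` gives 871 nM, a markedly higher number that lies beyond the scatter. Compound 3 `N#Cc1c(N2CCC(c3ccccc3)CC2)ccn(CC2CCC2)c1=O` differs from compound 2 by cyclobutyl in place of propyl on a saturated chain carbon bound to an aromatic nitrogen. Going by the values given here, no measured pair shows a change of this kind, so the expected step of a 1.1-fold lower number from compound 2 to compound 3 (0.02 log units; within the scatter) in this assay is none beyond the scatter, with no direction favoured. Compound 3 is therefore estimated to give 90 nM, within a range from 30 nM to 270 nM.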

Compound 3, half-maximal effective concentration: 55 nM
For compound 3 the middle estimate is 1.6-fold (0.21 log units) above the measured one; measured number inside the range.
By their numbers in this assay, from the lowest: compounds 3 and 2 (each within the scatter of the next); then compound 1.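

On a saturated chain carbon bound to an aromatic nitrogen, cyclobutyl in place of propyl gives a 1.7-fold lower number from compound 2 to compound 3 (0.24 log units; within the scatter) in this assay, so a ring at this position leaves the number within the scatter. For the compounds shown here, this is the first pair that differs in one place, and it gives a reading for this position alone. No measurement available here bears on the reason for this result.

As far as these compounds go, how an amine, a carboxylic acid or a longer chain at this position would read remains open. Also open, from the compounds shown here alone, is whether cyclobutyl gives a similar result on the core of compound 1.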